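The source may hold more compounds than are shown below. What is called first, only, known or untested is meant among the compounds shown, and "the series" means these compounds.

Three compounds were measured in a functional assay on A549 cells (Homo sapiens) for antiproliferative activity, read by MTT assay, with a stated time of 48 h; on this read-out higher numbers stand for weaker inhibition and lower numbers for stronger inhibition:

compound 1 `O=c1cc(-n2cc(CSc3ccccc3)nn2)c2cc(Br)ccc2o1` gives 3510 nM
compound 2 `O=c1cc(-n2cc(COc3ccccc3)nn2)c2cc(Br)ccc2o1` gives 12300 nM
compound 3 `O=c1cc(-n2cc(COc3ccccc3O)nn2)c2cc(Br)ccc2o1` gives 7940 nM

Compound 3 stands second highest of the three; its nearest neighbour is compound 2, and the step of a 1.5-fold lower number from compound 2 to compound 3 (0.19 log units; within the scatter) lies within the scatter, so the two cannot be ordered. Compound 1 sits clearly lower, as the step of a 2.3-fold higher number from compound 1 to compound 3 (0.35 log units; beyond the scatter) shows.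

Compound 4 `O=c1cc(-n2cc(COc3ccc(Br)cc3)nn2)c2cc(Br)ccc2o1` differs from compound 3 in one place: 4-bromophenyl in place of 2-hydroxyphenyl on an oxygen on a saturated carbon. Of the measured steps only a 1.5-fold lower number from compound 2 to compound 3 (0.19 log units; within the scatter) touches this change, and it covers just the hydroxy, not the bromine; it was within the scatter. Among the measured compounds shown here, no measured pair shows what a bromine on this ring does. The step of a 1.1-fold higher number from compound 3 to compound 4 (0.05 log units; within the scatter) is therefore expected to be small, with no clear direction beyond the scatter, and the range must stay wide. Compound 4 is estimated at 9000 nM, between 3000 nM and 27000 nM.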

Compound 4, half-maximal inhibitory concentration: 24500 nM
Beside the measured number, compound 4's estimate is 2.7-fold (0.43 log units) below it; measured number inside the range.
By their numbers in this assay, from the lowest: compound 1; then compounds 3, 2 and 4 (each within the scatter of the next, the first and the last beyond it).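

In this assay, the bromine can now be read on its own: bromo in place of hydrogen on an aromatic carbon gives a 2.0-fold higher number from compound 2 to compound 4 (0.30 log units; within the scatter), so this ring with and without bromine cannot be told apart. Replacing 2-hydroxyphenyl with 4-bromophenyl removes the hydroxy and adds the bromine at once and gives a 3.1-fold higher number from compound 3 to compound 4 (0.49 log units; beyond the scatter), while 4-bromophenoxy in place of phenylsulfanyl gives a 7.0-fold higher number from compound 1 to compound 4 (0.84 log units; beyond the scatter), the largest step among these compounds. Nothing available here explains why these numbers differ.

From the compounds shown here alone, it remains open whether a bromine on the phenylsulfanyl ring of compound 1 would give a similar step. Also open, going by these compounds, is how an amine or a carboxylic acid in place of the bromine of compound 4 would read out.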